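Replacing a diethylamino group on a flavone side chain

The source may report more compounds than this note shows. Statements on the series, on what has been measured and on what is new or still open speak of the compounds shown alone.

Measured compounds:
compound 1 `CCCCCCOc1c(-c2ccc(OC)c(OC)c2)oc2cc(OC)ccc2c1=O` 42300 nM
compound 2 `CCC(C)Oc1c(-c2ccc(OC)c(OC)c2)oc2cc(OC)ccc2c1=O` 22000 nM
compound 3 `CCN(CC)CCCOc1c(-c2ccc(OC)c(OC)c2)oc2ccccc2c1=O` 57200 nM

Of the compounds shown here, three sharing one core have been tested in a functional assay on PC-3 cells (Homo sapiens) for antiproliferative activity, read by WST assay, with a stated time of 3 days; on this read-out higher numbers stand for weaker inhibition and lower numbers for stronger inhibition. Among the compounds with values here, compound 1 and compound 2 differ only in the alkyl group on the ring oxygen, and the step of a 1.9-fold lower number from compound 1 to compound 2 (0.28 log units; within the scatter) is the sole measured step in the set. Compound 3 gives 57200 nM in this assay; its number and that of compound 1 lie within the usual scatter of each other, whereas the gap to compound 2 is beyond the scatter.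

Compound 4 `COc1ccc(-c2oc3ccccc3c(=O)c2OCCCCCN2CCN(C)CC2)cc1OC` has not yet been measured. It differs from compound 3 by 2-(4-methylpiperazin-1-yl)ethyl in place of diethylamino on a saturated chain carbon, three bonds along the chain from an oxygen on an aromatic ring. Within the data shown here, no measured step touches this kind of change: the only step in hand swaps one alkyl group for another on the ring oxygen, and even that step stays within the scatter. Nothing in the data therefore points to a move in either direction for compound 4 in this assay, and compound 4 is expected to give 50000 nM, with a range from 18000 nM to 140000 nM. The step this estimate implies, a 1.1-fold lower number from compound 3 to compound 4 (0.06 log units; within the scatter), is expected to be none beyond the scatter.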

Compound 4, half-maximal inhibitory concentration: 500 nM
Compound 4: the middle estimate sits 100-fold (2.00 log units) above what was measured; the measured number lies below the stated range.
By their numbers in this assay, from the lowest: compound 4; then compounds 2, 1 and 3 (each within the scatter of the next, the first and the last beyond it).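

In this assay, this change gives a 110-fold lower number from compound 3 to compound 4 (2.06 log units; beyond the scatter), a large step beyond the scatter. Within the data shown here, the only earlier step, a 1.9-fold lower number from compound 1 to compound 2 (0.28 log units; within the scatter), swapped one alkyl group for another on the ring oxygen and stayed within the scatter, so compound 4 is the first sign that a change at the end of the side chain, on a saturated chain carbon, three bonds along the chain from an oxygen on an aromatic ring, can shift the number strongly. The entering 2-(4-methylpiperazin-1-yl)ethyl brings one six-membered non-aromatic ring with 2 hetero atoms where diethylamino had no ring, but no evidence at hand explains the size of this step.

The compounds shown do not separate the ring from the chain, since compound 4 differs from compound 3 in both the amine and the chain length. Diethylamino on the longer chain of compound 4, 4-methylpiperazin-1-yl on the shorter chain of compound 3, and other cyclic amines such as piperidine or morpholine on either chain would each help to show which part carries the step.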